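The compounds below may be only part of what the source reports. "The series", "measured", "known", "first", "only" and "open" are said of these compounds alone.

Among the compounds with values here, compound 1 `CC(=O)OC/C1=C/C[C@](C)(CCC=C(C)C)/C=C/[C@@H](OC(=O)C=C(C)C)[C@](C)(O)/C=C/C1=O` is one of two compounds measured in a functional assay on SW480 cells (Homo sapiens) for antiproliferative activity, read by MTT assay, with a stated time of 48 h (a lower number here means a stronger inhibitor, a higher number a weaker inhibitor), and in this assay compound 1 gives 2950 nM. The other measured compound, compound 2 `CO[C@]1(C)/C=C/C(=O)/C(CO)=C\C[C@](C)(CCC=C(C)C)/C=C/[C@H]1OC(=O)C=C(C)C`, carries a methoxy and a free hydroxymethyl on the shared core, and in this assay compound 2 gives 15200 nM. Compound 1 thus stands at the lower of the two numbers, and its gap to compound 2 lies beyond the usual scatter.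

Compound 3 `CC(C)=CCC[C@]1(C)/C=C/[C@@H](OC(=O)C=C(C)C)[C@](C)(O)/C=C/C(=O)/C(C[Si](C)(C)C(C)(C)C)=C\C1` has not yet been measured. It differs from compound 1 in a single place: a group of 7 heavy atoms (6 carbon, 1 silicon; no ring) in place of a group of 4 heavy atoms (2 carbon, 2 oxygen; no ring), on a saturated chain carbon bound to a double-bonded ring carbon. The acetoxy leaves and the group of 7 heavy atoms (6 carbon, 1 silicon; no ring) enters on a saturated chain carbon bound to a double-bonded ring carbon. Within the data shown here, no measured pair isolates this change, and compound 2 differs from compound 1 elsewhere on the core, so its value offers no direct guide. Compound 3 is therefore expected to stay close to compound 1, with a step of a 1.4-fold higher number from compound 1 to compound 3 (0.13 log units; within the scatter) that is estimated to be small, toward a weaker inhibitor, and probably not beyond the scatter. In this assay compound 3 is expected to give 4000 nM, with a likely range from 1500 nM to 12000 nM.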

Compound 3, half-maximal inhibitory concentration: 3350 nM
For compound 3 the middle estimate is 1.2-fold (0.08 log units) above the measured one; low and high end bracket the measured number.
By their numbers in this assay, from the lowest: compounds 1 and 3 (each within the scatter of the next); then compound 2.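

In this assay, within the data shown here, the exchange of the acetoxy for the group of 7 heavy atoms (6 carbon, 1 silicon; no ring), on a saturated chain carbon bound to a double-bonded ring carbon, gives a 1.1-fold higher number from compound 1 to compound 3 (0.06 log units; within the scatter), the first measured step at this place. The acetoxy brings 2 hydrogen-bond acceptors and the entering group brings 0, yet in this pair the exchange leaves the number within the scatter, so for this pair the acetoxy is not required to keep compound 3 level with compound 1. No supporting measurement bears on why the two compounds read alike.

The compounds shown leave open whether this holds for other groups on the same carbon, such as an amine, a carboxylic acid or a longer chain, as this one pair speaks only for a single exchange. Among these compounds, they also leave open what the methoxy and the free hydroxymethyl of compound 2 each contribute, as compound 2 carries both differences at once and no measured pair separates them.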